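Cytotoxicity notes on the shared core, compound 2 to 3

The source may report more compounds than this note shows. Statements on the series, on what has been measured and on what is new or still open speak of the compounds shown alone.

Measured so far in an ADME assay on Huh-7 cells (Homo sapiens) for cytotoxicity, with a stated time of 72 h; on this read-out higher numbers stand for lower toxicity in this test and lower numbers for higher toxicity in this test:
- compound 1 `CS(=O)(=O)Nc1ccc2c(c1)S(=O)(=O)N=C(C1=C(O)C3CCCC3N(Cc3ccc(Cl)cc3)C1=O)N2`: > 10000 nM, a limit of the assay
- compound 2 `CC(C)CCN1C(=O)C(C2=NS(=O)(=O)c3cc(NS(C)(=O)=O)ccc3N2)=C(O)C2CCCC21`: > 1000 nM, a limit of the assay

In this assay compound 2 gives > 1000 nM, which is a limit and not a number. Among the compounds with values here, the only step available, a step that the two limits leave unreadable from compound 1 to compound 2, cannot be read because both ends are limits (the limit of > 1000 nM in this assay, at which 1 of the 2 values shown sits, (the limit of > 10000 nM in this assay, at which 1 of the 2 values shown sits)). Compound 3 `CCN1C(=O)C(C2=NS(=O)(=O)c3cc(NS(C)(=O)=O)ccc3N2)=C(O)C2CCCC21` differs from compound 2 by hydrogen in place of isopropyl on a saturated chain carbon, two bonds along the chain from an amide-type nitrogen in a ring, a change at a saturated chain carbon two bonds from the ring amide-type nitrogen. Within the data shown here, no measured step touches this position, so no direction of change is expected beyond the scatter; with both neighbours sitting at limits, compound 3 is expected to sit at a limit as well. The estimate for compound 3 is 15000 nM with range 5000 nM to 50000 nM, meaning an expected step that the limit leaves unreadable from compound 2 to compound 3.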

Compound 3, half-maximal cytotoxic concentration: > 33000 nM
Compound 3: a limit, no number; the forecaster's own chance of this, stated with the estimate: 85%; middle value at least 2.2-fold (0.34 log units) from the limit.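

Within the data shown here, compound 1, compound 2 and compound 3 all give limits and not numbers in this assay, and no step among them can be read. The compounds shown leave open whether any of these chains gives a numerical half-maximal cytotoxic concentration in this assay, and how isopentyl and ethyl truly compare.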